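Efficacy at the Urethral Receptor: From Methyl to Methoxy

The source may report more compounds than this note shows. Statements on the series, on what has been measured and on what is new or still open speak of the compounds shown alone.

Measured compounds:
compound 1 `CS(=O)(=O)Nc1ccc(F)c2c1CCCC2c1c[nH]cn1` gives 64%
compound 2 `Cc1ccc(NS(C)(=O)=O)c2c1C(c1c[nH]cn1)CCC2` gives 35%

Both compounds were tested in a functional assay on Urethra with Alpha-1A adrenergic receptor (Oryctolagus cuniculus) as the target; on this read-out lower numbers stand for smaller maximal responses and higher numbers for larger maximal responses. Among the measured compounds shown here, compound 2 stands lowest of the two numbers measured; its nearest neighbour is compound 1, and the one measured step, a number 29 percentage points lower from compound 1 to compound 2 (beyond the scatter), lies beyond the scatter and was modest in size. Compound 3 `COc1ccc(NS(C)(=O)=O)c2c1C(c1c[nH]cn1)CCC2` is the next compound in this series and has not yet been measured in this assay. It differs from compound 2 in one place: methoxy in place of methyl on an aromatic carbon.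

For the measured compounds named here, only one step is known, and it concerns the exchange of fluoro for methyl, not of methyl for methoxy. It therefore bears on the new step only loosely, showing that a small change at this aromatic carbon moved the maximal response by a modest amount. Going by the values given here, no measured pair tells how a methoxy group behaves here. The expectation for compound 3 is accordingly a step close to none beyond the scatter, a number 5 percentage points higher from compound 2 to compound 3 (within the scatter), with a wide range in either direction. The estimate for compound 3 is 40%, between 15% and 70%.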

Compound 3, largest response reached (reported as efficacy), in percent of the reference or control that the assay uses: 57%
Compound 3: middle estimate off by 17 percentage points, on the low side; low and high end bracket the measured number.
By their numbers in this assay, from the lowest: compound 2; then compounds 3 and 1 (each within the scatter of the next).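

In this assay, methoxy in place of methyl on this aromatic carbon, para to a methanesulfonamido group, gives a number 22 percentage points higher from compound 2 to compound 3 (beyond the scatter) and so shows that a small exchange here can raise the maximal response as well as lower it. The drop seen on going from fluoro to methyl is therefore not what every replacement of fluoro at this carbon does, since methoxy in place of fluoro gives a number 7 percentage points lower from compound 1 to compound 3 (within the scatter) and the two groups cannot be told apart on this read-out. Of the three groups at this carbon, methyl alone stands apart, with compound 2 beyond the scatter of both other compounds.

From the compounds shown here alone, how a hydroxy group, a chlorine atom, an ethyl chain or an amine would behave on the same carbon stays open, and so does whether the oxygen of methoxy itself matters for the response. Three groups are too few to show what sets the maximal response at this carbon, and no supporting measurement accounts for these shifts.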